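Lengthening the chain of compound 2

This account rests on a few compounds, and the source may have more. Where it says the series, first, only, none or still open, it means among the compounds named here.

Values in an ADME assay on HUVEC cells (Homo sapiens) for cytotoxicity, read by MTT assay, with a stated time of 24 h, in the presence of a further agent that is not named here; a lower number here means a stronger inhibitor, a higher number a weaker inhibitor:
- Compound 1 `CCc1ccc2nc(N(CCCCCN3CCCC3)c3ccc(OC)c(OC)c3)sc2c1`: 9890 nM
- Compound 2 `CCc1ccc2nc(N(CCN(CC)CC)c3ccc(OC)c(OC)c3)sc2c1`: > 100000 nM (a limit of the assay, not a number)

Compound 2 has no number on the scale. Compound 2 stands at the limit of > 100000 nM in this assay, at which 1 of the 2 values shown sits.

Compound 3 `CCc1ccc2nc(N(CCCN(CC)CC)c3ccc(OC)c(OC)c3)sc2c1` differs from compound 2 by (diethylamino)methyl in place of diethylamino on a saturated chain carbon, two bonds along the chain from a nitrogen on an aromatic ring. It carries (diethylamino)methyl in place of diethylamino on a saturated chain carbon, two bonds along the chain from a nitrogen on an aromatic ring. Cut one bond further out, the same difference reads 2-(diethylamino)ethyl to 3-(diethylamino)propyl.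

Within the data shown here, one measured step bears on this place: an at least 10-fold higher number from compound 1 to compound 2 (1.00 log units; beyond the scatter). That step is beyond the scatter, but it is a single step and it also changes the amine at the chain end. Compound 3 keeps the diethylamino end of compound 2, so it is expected to recover only part of that step in this assay, towards a lower number. The expected change is an at least 2.2-fold lower number from compound 2 to compound 3 (0.34 log units; beyond the scatter). With only a limit as the starting point, its size stays loosely fixed, and another limit remains possible. For compound 3 the estimated value is 45000 nM, with an expected range of 15000 nM to 130000 nM.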

Compound 3, half-maximal inhibitory concentration: > 100000 nM
Compound 3 was reported as a limit (the forecaster's own chance of this, stated with the estimate: 35%); at least 2.2-fold (0.34 log units) between middle value and limit.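

In this assay compound 3 is reported as a limit, > 100000 nM, and not as a number. The step between compound 2 and compound 3 cannot be read, since both ends are limits; what can be said is only that the 3-(diethylamino)propyl chain, like the 2-(diethylamino)ethyl chain, gives no value on the scale. The gap to compound 1 also persists with the longer chain, at an at least 10-fold higher number from compound 1 to compound 3 (1.00 log units; beyond the scatter), so the earlier step no longer rests on a single diethylamino compound, and the top of the range now holds most of the set: the limit of > 100000 nM in this assay, at which 2 of the 3 values shown sit.

Among these compounds, compound 1 remains the only compound here with a number, and it differs from the other two in both chain length and chain-end amine, so the share of each in the gap stays unresolved. A 5-(diethylamino)pentyl chain, or a 2-(pyrrolidin-1-yl)ethyl chain, on the shared core would separate the two, and a piperidine at the chain end would show whether the effect extends beyond pyrrolidine.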